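Swapping methyl for fluoro on the aryl piperazine of compound 3

The source may hold more compounds than are shown below. What is called first, only, known or untested is meant among the compounds shown, and "the series" means these compounds.

Three compounds sharing one core have been examined. Compound 1 `CCC(C(=O)N1CCN(c2ccc(Cl)cc2)CC1)N1C(=O)CCC1=O` and compound 2 `CCC(C(=O)N1CCN(c2ccccc2)CC1)N1C(=O)CCC1=O` both reach a modest read-out in a functional assay on the whole organism (strain Swiss) with Mus musculus as the target, in the maximal electroshock model, with a stated time of 2 h, at a dose of 300 mg/kg by the intraperitoneal route; a lower number here means a weaker effect, a higher number a stronger effect of the compound at the dose given: compound 1 gives 25% and compound 2 gives 25%. Between them, no change at the digits printed from compound 1 to compound 2 (within the scatter), so the chloro on the aromatic ring makes no visible difference. Within the data shown here, compound 3 `CCC(C(=O)N1CCN(c2cccc(C)c2)CC1)N1C(=O)CCC1=O`, by contrast, gives 0% in this assay and stands lowest of the three; the drop is seen in a number 25 percentage points lower from compound 1 to compound 3 (beyond the scatter) and again in a number 25 percentage points lower from compound 2 to compound 3 (beyond the scatter), where a methyl is the only added group.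

Compound 4 `CCC(C(=O)N1CCN(c2cccc(F)c2)CC1)N1C(=O)CCC1=O` is not yet measured. It differs from compound 3 in one place: fluoro in place of methyl on an aromatic carbon, on an aromatic carbon meta to a large group. Among the measured compounds shown here, two measured steps bear on this. Compound 2 to compound 3 shows that putting the methyl on this ring cost the activity, and compound 1 to compound 2 shows that a halogen on the ring neither adds nor takes anything. Removing the methyl and placing a fluoro is therefore expected to recover the activity of compounds 1 and 2 rather than to go lower, with a number 25 percentage points higher from compound 3 to compound 4 (beyond the scatter) expected. Compound 4 is estimated at 25% in this assay, within 0% to 50%.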

Compound 4, a percentage reported as activity, at one dose (the size of the read-out at that dose, not a potency): 0%
Estimate against measurement, compound 4: 25 percentage points above, within the range that was stated.
By their numbers in this assay, from the lowest: compounds 3 and 4 (each within the scatter of the next); then compounds 1 and 2 (each within the scatter of the next).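

In this assay there is no change at the digits printed from compound 3 to compound 4 (within the scatter), so on this aromatic carbon, meta to a large group, fluoro and methyl cannot be told apart, and the loss first seen with the methyl is not confined to that one group. There is also a number 25 percentage points lower from compound 2 to compound 4 (beyond the scatter) and a number 25 percentage points lower from compound 1 to compound 4 (beyond the scatter), so a halogen on the ring does not always leave the read-out unchanged, as the step from compound 1 to compound 2 alone had suggested, although the step from compound 1 to compound 4 changes the halogen and its place together and cannot separate the two. Nothing available here offers an explanation of why the fluoro and the methyl give the same result at this place.

The compounds shown leave open whether a larger or differently built group on the same carbon, such as a methoxy group, a trifluoromethyl group or an amine, would also go with the lower read-out. They also leave open whether a 3-chlorophenyl or a 4-fluorophenyl would side with compound 4 or with compound 1, which would show whether the place or the halogen decides the outcome.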